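The source may hold more compounds than are shown below. What is called first, only, known or untested is meant among the compounds shown, and "the series" means these compounds.

Three compounds share one core, and two of them have a number in an assay on microsomes for inhibition of acyl-CoA desaturase 1 (Mus musculus), with a stated time of 60 min; on this read-out lower numbers stand for stronger inhibition and higher numbers for weaker inhibition. Compound 1 `COc1ccc(/C=C/C(=O)Nc2ncc(Cc3cccc(C(F)(F)F)c3)s2)cc1` gives 2 nM in this assay. Compound 2 `O=C(Nc1ncc(Cc2cccc(C(F)(F)F)c2)s1)c1ccc2ccccc2c1` reaches only the limit of this assay, reported as > 10000 nM; this is a limit and not a number. Compound 3 `Cc1ccc(C(=O)Nc2ncc(Cc3cccc(C(F)(F)F)c3)s2)cc1C` gives 8220 nM, the highest of the two numbers shown, and its gap to compound 1 lies far beyond the scatter of repeated measurements.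

Compound 4 `COc1cccc(C(=O)Nc2ncc(Cc3cccc(C(F)(F)F)c3)s2)c1` has not yet been measured. It differs from compound 3 in one place: 3-methoxyphenyl in place of 3,4-dimethylphenyl on a carbonyl carbon. Within the data shown here, no measured pair shows this change, so the expected size of the step rests on compound 3 alone, whose value 8220 nM sits among the weak inhibitors here. The step from compound 3 to compound 4 is expected to be small or within the scatter, a 1.6-fold lower number from compound 3 to compound 4 (0.22 log units; within the scatter). Compound 4 is estimated to give 5000 nM in this assay, between 1000 nM and 20000 nM.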

Compound 4, half-maximal inhibitory concentration: 193 nM
Beside the measured number, compound 4's estimate is 26-fold (1.41 log units) above it; measured number below the stated range.
By their numbers in this assay, from the lowest: compound 1; then compound 4; then compound 3. At a limit, above all of these: compound 2.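

In this assay the swap of 3,4-dimethylphenyl for 3-methoxyphenyl on a carbonyl carbon gives a 43-fold lower number from compound 3 to compound 4 (1.63 log units; beyond the scatter), so the group at this position can move the number strongly. The two groups count the same number of heavy atoms and each holds one six-membered aromatic ring; the entering group has one hydrogen-bond acceptor and the leaving group has none. Nothing shown here accounts for the size of this step.

From the compounds shown here alone, it remains open whether the step follows from the methoxy group arriving or from the two methyl groups leaving, as the two happen together in this one change. An unsubstituted phenyl ring, or a phenyl ring carrying a single methyl group, on the same carbonyl carbon would help to separate these two parts.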